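The source may report more compounds than this note shows. Statements on the series, on what has been measured and on what is new or still open speak of the compounds shown alone.

Going by the values given here, compound 2 `CO[C@H]1CC[C@@H](CNc2cc(NCc3cnccc3C(F)(F)F)ncc2C#N)CC1` is the stronger of the two compounds measured so far: in an assay on isolated protein for inhibition of protein kinase C theta type (Homo sapiens), read by TR-FRET, with a stated time of 2 h (on this read-out lower numbers stand for stronger inhibition and higher numbers for weaker inhibition), compound 2 gives 70 nM, whereas compound 1 `CO[C@H]1CC[C@H](Nc2cc(NCc3cnccc3C(F)(F)F)ncc2C#N)CC1` gives 1100 nM. Among the compounds with values here, the single recorded step, a 16-fold lower number from compound 1 to compound 2 (1.20 log units; beyond the scatter), is large and concerns only whether the saturated ring reaches the nitrogen through one extra carbon. Compound 3 `N#Cc1cnc(NCc2cnccc2C(F)(F)F)cc1NC1CCOCC1` carries oxan-4-yl in place of (4-methoxycyclohexyl)methyl on a nitrogen on an aromatic ring, so its ring is once more joined directly to the nitrogen, as in compound 1. On that basis compound 3 is expected to show a clearly higher number, a 13-fold higher number from compound 2 to compound 3 (1.11 log units; beyond the scatter), with an estimated value of 900 nM and a likely range from 250 nM to 3500 nM.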

Compound 3, half-maximal inhibitory concentration: 900 nM
Compound 3: middle estimate and measured number agree at the digits printed; low and high end bracket the measured number.
By their numbers in this assay, from the lowest: compound 2; then compounds 3 and 1 (each within the scatter of the next).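

In this assay, exchanging the ring joined directly to the nitrogen makes little difference: oxan-4-yl in place of 4-methoxycyclohexyl gives a 1.2-fold lower number from compound 1 to compound 3 (0.09 log units; within the scatter). Compound 2 stands apart from both directly joined compounds, with a 13-fold higher number from compound 2 to compound 3 (1.11 log units; beyond the scatter), a large step that changes the ring and its link together. No evidence is available to explain these numbers.

On these data alone, it remains open whether oxan-4-ylmethyl on the same nitrogen would match the number of compound 2. Also open, as far as these compounds go, is what a longer chain between nitrogen and ring, or a ring carrying an amine, would give.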